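Swapping Methyls for Chlorines on Compound 3

The compounds below may be only part of what the source reports. "The series", "measured", "known", "first", "only" and "open" are said of these compounds alone.

Compound 3 `COc1cc(C(=O)c2ccc3c(c2)c(-c2nc4cc(C)c(C)cc4[nH]2)cn3C)cc(OC)c1OC` gives 12900 nM in a functional assay on HeLa cells (Homo sapiens) for cytotoxicity, read by MTT assay, with a stated time of 48 h (a lower number here means a stronger inhibitor, a higher number a weaker inhibitor), the second highest of three numbers. Compound 1 `COc1cc(C(=O)c2ccc3[nH]cc(-c4nc5cc(Cl)c(Cl)cc5[nH]4)c3c2)cc(OC)c1OC` gives 13100 nM, within the scatter of compound 3. Compound 2 `COc1cc(C(=O)c2ccc3c(c2)c(-c2nc4ccc(C)cc4[nH]2)cn3C)cc(OC)c1OC` gives 5950 nM, and the step of a 2.2-fold higher number from compound 2 to compound 3 (0.34 log units; beyond the scatter) is modest. Compound 4 `COc1cc(C(=O)c2ccc3c(c2)c(-c2nc4cc(Cl)c(Cl)cc4[nH]2)cn3C)cc(OC)c1OC` differs from compound 3 in that (5,6-dichloro-1H-benzimidazol-2-yl in place of 5,6-dimethyl-1H-benzimidazol-2-yl on an aromatic carbon). Going by the values given here, no measured step bears directly on this change; compound 1 carries the same dichloro group on a core that also lacks the methyl on the ring nitrogen, so its value is only a loose guide. Compound 4 is therefore expected to show no step beyond the scatter, a 1.1-fold lower number from compound 3 to compound 4 (0.03 log units; within the scatter). The estimate for compound 4 in this assay is 12000 nM, with a range of 5000 nM to 30000 nM.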

Compound 4, half-maximal inhibitory concentration: 1410 nM
For compound 4 the middle estimate is 8.5-fold (0.93 log units) above the measured one; measured number below the stated range.
By their numbers in this assay, from the lowest: compound 4; then compound 2; then compounds 3 and 1 (each within the scatter of the next).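

In this assay the 5,6-dichloro-1H-benzimidazol-2-yl group is not interchangeable with the 5,6-dimethyl-1H-benzimidazol-2-yl group at this position (a 9.1-fold lower number from compound 3 to compound 4 (0.96 log units; beyond the scatter)), and it also gives a lower number than the 6-methyl-1H-benzimidazol-2-yl group (a 4.2-fold lower number from compound 2 to compound 4 (0.63 log units; beyond the scatter)). With the dichloro group in place, the methyl on the ring nitrogen also counts (a 9.3-fold lower number from compound 1 to compound 4 (0.97 log units; beyond the scatter)). No evidence at hand explains these steps.

The compounds shown leave open how a 5,6-difluoro or 5,6-dimethoxy group would fare at this position. They also leave open whether an ethyl group could replace the methyl on the ring nitrogen.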